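Ester to amide on an indole acrylonitrile core

This account rests on a few compounds, and the source may have more. Where it says the series, first, only, none or still open, it means among the compounds named here.

Measured compounds:
Compound 1, `NC/C(=C\c1ccc(O)c(O)c1)C(=O)O`, gives 50.1%.
Compound 2, `N#C/C(=C\c1cc2ccccc2[nH]1)C(=O)O`, gives 25.8%.
Compound 3, `CC(C)CCOC(=O)/C(C#N)=C/c1cc2ccccc2[nH]1`, gives 46.6%.

All three were tested in a functional assay on the whole organism (strain CD1) for inhibition, with Mus musculus as the target, with stated times of 15 min and 20 min, at a dose of 10 mg/kg by the subcutaneous route; on this read-out lower numbers stand for less inhibition and higher numbers for more inhibition at the one dose given (going by the name of the read-out). Compound 3 stands second highest of the three numbers; its nearest neighbour is compound 1, whose value lies within the usual scatter of that of compound 3, while compound 2 lies furthest away, beyond the scatter. Among the measured compounds shown here, the only step between two measured compounds that differ in one place is a number 20.8 percentage points higher from compound 2 to compound 3 (beyond the scatter), a modest rise when the acid of compound 2 becomes the ester of compound 3.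

Compound 4, `N#C/C(=C\c1cc2ccccc2[nH]1)C(=O)NC1CCCCC1`, has not yet been measured. It differs from compound 3 in one place: cyclohexylamino in place of isopentyloxy on a carbonyl carbon. For the measured compounds named here, the measured step concerns the oxygen of the ester and not the carbonyl carbon itself, so it bears only loosely on this change; no pair among the measured compounds shows what swapping an ester for an amide does here. The expectation is therefore no step beyond the scatter, a number 1.6 percentage points lower from compound 3 to compound 4 (within the scatter). Compound 4 is estimated at 45%, with a range from 25% to 65%.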

Compound 4, a percentage reported as inhibition, in the whole organism at one dose (the size of the read-out at that dose, not a potency): 45%
The estimate for compound 4 equals the measured number at the digits printed, within the range that was stated.
By their numbers in this assay, from the lowest: compound 2; then compounds 4, 3 and 1 (each within the scatter of the next).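

In this assay the carbonyl carbon takes cyclohexylamino in place of isopentyloxy with a number 1.6 percentage points lower from compound 3 to compound 4 (within the scatter) and so the ester and the amide cannot be told apart at this dose, even though the change brings in a six-membered ring and a hydrogen-bond donor. The acid now has a second comparison, a number 19.2 percentage points higher from compound 2 to compound 4 (beyond the scatter) and this sits alongside a number 20.8 percentage points higher from compound 2 to compound 3 (beyond the scatter) to show that replacing hydroxy on this carbonyl carbon with either an isopentyloxy or a cyclohexylamino group goes with a number beyond the scatter of the acid. Nothing else measured on these compounds accounts for this result.

Because the linking atom and the carbon group change together in this step, the compounds shown cannot separate the two, and an isopentylamino group on the same carbonyl carbon would hold the chain while changing only the oxygen to nitrogen. As far as these compounds go, it also remains open whether a much smaller group such as methylamino, or a morpholine amide that has no amide hydrogen, would keep the number at the level of compound 3 and compound 4.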